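The source may hold more compounds than are shown below. What is called first, only, known or untested is meant among the compounds shown, and "the series" means these compounds.

Compound 1, `Nc1oncc1-c1ccccc1`: 85 nM
Compound 2, `c1ccc(-c2cnoc2)cc1`: > 25000 nM
Compound 3, `CNC(=O)c1oncc1-c1ccccc1`: > 25000 nM

These three compounds share one core and differ only in the group on one aromatic carbon. For the measured compounds named here, in an assay on SW48 cells for inhibition of Tryptophan 2,3-dioxygenase (Homo sapiens), read by fluorescence, with a stated time of 30 min (on this read-out lower numbers stand for an effect already at smaller amounts and higher numbers for an effect only at larger amounts of compound), compound 1 gives 85 nM, the only plain number among the three. For compound 2 the assay reports only a limit, > 25000 nM. For compound 3 it likewise reports only a limit, > 25000 nM. The step of an at least 290-fold higher number from compound 1 to compound 2 (2.46 log units; beyond the scatter) and the step of an at least 290-fold higher number from compound 1 to compound 3 (2.46 log units; beyond the scatter) both run beyond the scatter, while the step that the two limits leave unreadable from compound 2 to compound 3 cannot be read because of the limit of > 25000 nM in this assay, at which 2 of the 3 values shown sit. Going by the values given here, compound 1 thus stands alone as the one compound with a measurable number.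

Compound 4, `Cc1noc(N)c1-c1ccccc1`, keeps the amino group of compound 1 and adds a small group at another place: methyl in place of hydrogen on an aromatic carbon. Among the compounds with values here, none of the measured steps touches this position; each of them replaces the amino group, which compound 4 retains. They therefore give no direct guide, beyond showing that replacing the amino group of compound 1 produced large steps. For a change of this size at an untested position, the step of a 1.2-fold higher number from compound 1 to compound 4 (0.07 log units; within the scatter) is expected to stay within the scatter. Compound 4 is accordingly estimated at 100 nM, with a range from 30 nM to 400 nM.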

Compound 4, half-maximal effective concentration: 9700 nM
Beside the measured number, compound 4's estimate is 97-fold (1.99 log units) below it; the whole stated range lies below it.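

This result shows that the carbon next to the ring nitrogen, which carries only a hydrogen in compound 1, is not a place where a change passes unnoticed. In this assay, methyl in place of hydrogen on this carbon gives a 110-fold higher number from compound 1 to compound 4 (2.06 log units; beyond the scatter), so a single added carbon is enough for a large step, and keeping the amino group does not by itself preserve the low number of compound 1. The data shown offer no measured property that would explain why this small change has so large an effect.

On this carbon, the compounds shown carry only hydrogen and methyl, so it remains open how a fluorine atom, a hydroxyl group or a longer chain such as ethyl would behave there. Going by these compounds, it also remains open whether methyl on this carbon would give a step of similar size if another group, such as an acetyl group, stood in place of the amino group.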